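Working Notes: Compound 1 to Compound 4

The source may report more compounds than this note shows. Statements on the series, on what has been measured and on what is new or still open speak of the compounds shown alone.

Compound 1 `COc1cc(-n2ncnc2-c2ccc(C)cc2)cc(OC)c1OC` gives 540 nM in a functional assay on MCF7 cells (Homo sapiens) for antiproliferative activity, read by MTT assay, with a stated time of 72 h; a higher number here means a weaker inhibitor, a lower number a stronger inhibitor. Compound 3 `COc1ccc(-n2ncnc2-c2cc(OC)c(OC)c(OC)c2)cc1` gives 7400 nM in this assay. Compound 2 `COc1cc(-c2ncnn2-c2ccccc2)cc(OC)c1OC` reaches only > 10000 nM in this assay, which is a limit of the assay and not a number; (the limit of > 10000 nM in this assay, at which 1 of the 3 values shown sits). Among the two numbers compound 1 stands lowest, with compound 3 the nearest and that gap beyond the scatter. Among the measured compounds shown here, the single step between measured compounds, an at least 1.3-fold lower number from compound 2 to compound 3 (0.13 log units; that floor lies within the scatter), concerns methoxy in place of hydrogen on an aromatic carbon, and its floor lies within the scatter.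

Compound 4 `COc1cc(-n2ncnc2-c2cccc(Cl)c2)cc(OC)c1OC` differs from compound 1 by 3-chlorophenyl in place of 4-methylphenyl on an aromatic carbon. For the measured compounds named here, no measured step touches that change; the step from compound 2 to compound 3 sits on a different ring and is small at its floor, so it gives no direction here. The expected step is a 1.5-fold higher number from compound 1 to compound 4 (0.17 log units; within the scatter) in this assay, not reliably beyond the scatter. The estimate for compound 4 in this assay is 800 nM, with a range from 250 nM to 3000 nM.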

Compound 4, half-maximal inhibitory concentration: > 10000 nM
Compound 4 was reported as a limit (the forecaster's own chance of this, stated with the estimate: 5%); at least 12-fold (1.09 log units) between middle value and limit.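

At this position, on an aromatic carbon between two ring nitrogen atoms, the attached aryl group is not freely exchangeable: 3-chlorophenyl in place of 4-methylphenyl gives an at least 18-fold higher number from compound 1 to compound 4 (1.26 log units; beyond the scatter). Among the compounds shown here, the two groups match in heavy-atom count and ring type, so neither count nor ring type separates them, and this is the first measured step at this position. Compound 4 stands at a limit of the assay, not a number, so the step gives only a floor: the limit of > 10000 nM in this assay, at which 2 of the 4 values shown sit.

Whether the step follows the exchange of methyl for chlorine or the different place of the substituent on the phenyl ring stays open, as the compounds shown hold no pair that separates the two. Also open, from the compounds shown here alone, is how an amine or a carboxylic acid on that phenyl ring would read in this assay.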